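Replacing a branched alcohol tail with a short amine chain

A few compounds are considered here, and "the series" means these few. Any claim that something is new, unique, unknown or untested is made for them only; others in the source may bear on it.

Measured so far in an assay on HEK293 cells for agonist activity at Toll-like receptor 2 (Homo sapiens); on this read-out lower numbers stand for an effect already at smaller amounts and higher numbers for an effect only at larger amounts of compound:
compound 1 `CCCCCCCCCCCC(=O)OC[C@H](CSC[C@@H](N)C(=O)NCCCC(C)(C)CO)OC(=O)CCCCCCCCCCC`: 30700 nM
compound 2 `CCCCCCCCCCCC(=O)OC[C@H](CSC[C@@H](N)C(=O)N[C@@H](CC)COCC(=O)O)OC(=O)CCCCCCCCCCC`: 6500 nM
compound 3 `CCCCCCCCCCCC(=O)OC[C@H](CSC[C@@H](N)C(=O)NCCCCCC(=O)O)OC(=O)CCCCCCCCCCC`: 108 nM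

Compound 1 gives the highest number of the three, so it needs the largest amount for an effect. The change to compound 2 brings a 4.7-fold lower number from compound 1 to compound 2 (0.67 log units; beyond the scatter), and the change to compound 3 brings a 280-fold lower number from compound 1 to compound 3 (2.45 log units; beyond the scatter); between them lies a 60-fold lower number from compound 2 to compound 3 (1.78 log units; beyond the scatter). Both measured steps away from compound 1 exchange the branched alcohol end for a chain carrying a carboxylic acid, and both lower the number.

Compound 4 `CCCCCCCCCCCC(=O)OC[C@H](CSC[C@@H](N)C(=O)NCCCCN)OC(=O)CCCCCCCCCCC` differs from compound 1 as follows: aminomethyl in place of 1-(hydroxymethyl)-1-methylethyl on a saturated chain carbon, three bonds along the chain from an amide-type nitrogen. For the measured compounds named here, the nearest measured step is the one to compound 3, since it alters the same place and also removes the branching, but compound 3 ends in an acid and compound 4 in an amine, and the two remaining chains differ in length. The size of that step is therefore taken as an upper bound rather than a forecast. The expectation is a lower number for compound 4 than for compound 1, by a 20-fold lower number from compound 1 to compound 4 (1.31 log units; beyond the scatter), so that compound 4 is estimated at 1500 nM, within 150 nM to 15000 nM.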

Compound 4, half-maximal effective concentration: 1040 nM
Beside the measured number, compound 4's estimate is 1.4-fold (0.16 log units) above it, within the range that was stated.
By their numbers in this assay, from the lowest: compound 3; then compound 4; then compound 2; then compound 1.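

In this assay the step from the branched alcohol tail to 4-aminobutyl gives a 30-fold lower number from compound 1 to compound 4 (1.47 log units; beyond the scatter) and so shows that a large drop in the number does not require a carboxylic acid at the chain end. The acid-ended chain still gives the lowest number of the pair, with a 9.6-fold higher number from compound 3 to compound 4 (0.98 log units; beyond the scatter) on a step that changes chain length as well as the end group, while a 6.3-fold lower number from compound 2 to compound 4 (0.80 log units; beyond the scatter) shows that an amine-ended chain can also outdo a branched chain carrying an acid. Nothing available here explains these differences.

The compounds shown leave open how an amine at the end of a longer chain, matching the length in compound 3, would compare with that acid. They also leave open whether an unbranched chain ending in an alcohol would behave like compound 1 or like compound 4.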